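Shortening the side chain of compound 2

The compounds below may be only part of what the source reports. "The series", "measured", "known", "first", "only" and "open" are said of these compounds alone.

Compound 1 `COc1cccc(N2CCN(C(=O)C(C)N3C(=O)CCC3=O)CC2)c1` and compound 2 `CCC(C(=O)N1CCN(c2ccccc2Cl)CC1)N1C(=O)CCC1=O` carry the same core with different substitution. In a functional assay on the whole organism (strain Swiss) with Mus musculus as the target, in the maximal electroshock model, with a stated time of 2 h, at a dose of 300 mg/kg by the intraperitoneal route (a lower number here means a weaker effect, a higher number a stronger effect of the compound at the dose given), compound 1 gives 0%. In this assay compound 2 gives 0%, level with compound 1 at the digits shown; the two values sit within the usual scatter of each other, so nothing separates them. For the measured compounds named here, no single-site step between measured compounds exists in this set.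

Compound 3 `CC(C(=O)N1CCN(c2ccccc2Cl)CC1)N1C(=O)CCC1=O` is the unmeasured member. It differs from compound 2 by hydrogen in place of methyl on a saturated chain carbon, two bonds along the chain from an amide-type nitrogen in a ring and a carbonyl carbon; cut one bond further out, the same difference reads ethyl to methyl. The two measured compounds both rest at the floor of the read-out and give nothing on which to rest a move in either direction. The step from compound 2 to compound 3 is expected to be no change at the digits printed from compound 2 to compound 3 (within the scatter), none beyond the scatter. For compound 3 the expected value in this assay is 0%, within 0% to 10%.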

Compound 3, a percentage reported as activity, at one dose (the size of the read-out at that dose, not a potency): 0%
Compound 3: the middle estimate sits on the measured number at the digits printed, and the stated range covers the measured number.
By their numbers in this assay, from the lowest: compounds 1, 2 and 3 (each within the scatter of the next).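

In this assay, hydrogen in place of methyl on a saturated chain carbon, two bonds along the chain from an amide-type nitrogen in a ring and a carbonyl carbon, gives no change at the digits printed from compound 2 to compound 3 (within the scatter). For the compounds shown here, compound 3 also supplies the first two single-site steps: 2-chlorophenyl in place of 3-methoxyphenyl on an amine nitrogen in a ring gives no change at the digits printed from compound 1 to compound 3 (within the scatter). With both steps resting at the floor of the read-out, neither change can be credited with any contribution to the effect, and nothing measured here bears on the result.

As far as these compounds go, whether any group on this chain carbon can lift the read-out off the floor remains open. A longer chain, an amine or a carboxylic acid at this place would test this, as would other substituents on the phenyl ring.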